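Changing the halogenated anilide in pyrazole carboxamides

The compounds below may be only part of what the source reports. "The series", "measured", "known", "first", "only" and "open" are said of these compounds alone.

Compound 1 `Cc1cc(C(=O)Nc2cc(Cl)cc(Cl)c2)nn1-c1cccc(C(F)(F)F)c1`: 150 nM
Compound 2 `Cc1cc(C(=O)Nc2cccc(Br)c2)nn1-c1cccc(C(F)(F)F)c1`: 359 nM

In an assay on HEK293 cells for binding affinity to Neuropeptide Y receptor type 5 (Homo sapiens), read by radioligand binding (a higher number here means a weaker inhibitor, a lower number a stronger inhibitor), compound 2 gives the highest of the two numbers; its nearest neighbour is compound 1, which sits a 2.4-fold higher number from compound 1 to compound 2 (0.38 log units; beyond the scatter) away. Compound 3 `Cc1cc(C(=O)Nc2ccc(Cl)cc2)nn1-c1cccc(C(F)(F)F)c1` differs from compound 2 in one place: 4-chlorophenyl in place of 3-bromophenyl on an amide-type nitrogen. Within the data shown here, none of the measured steps changes a single halogen position on the anilide, so no measured step bears directly on this change. With compound 2 as the only anchor, the author expects a step of a 1.1-fold higher number from compound 2 to compound 3 (0.05 log units; within the scatter) in this assay, lying within the scatter. Compound 3 is therefore estimated at 400 nM, with a range from 130 nM to 1200 nM.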

Compound 3, half-maximal inhibitory concentration: > 1000 nM
Compound 3 was reported as a limit; the forecaster's own chance of this, stated with the estimate: 5%; middle value at least 2.5-fold (0.39 log units) from the limit.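

For compound 3, > 1000 nM in this assay is a limit of the assay, not a number. Even so, the anilide proves sensitive to which halogenated phenyl it carries: 4-chlorophenyl in place of 3-bromophenyl gives an at least 2.7-fold higher number from compound 2 to compound 3 (0.44 log units; beyond the scatter), and in place of 3,5-dichlorophenyl it gives an at least 6.6-fold higher number from compound 1 to compound 3 (0.82 log units; beyond the scatter). Compound 3 is thus the weakest of the three, and this position tolerates less than the earlier step suggested.

The step to 4-chlorophenyl changes the halogen and its place together, and the compounds shown cannot separate the two. Also open, from the compounds shown here alone, is what a nitrile or methoxy group would give in place of the halogen.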